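The source may hold more compounds than are shown below. What is called first, only, known or untested is meant among the compounds shown, and "the series" means these compounds.

Of the compounds shown here, three of a shared core have been measured in an assay on L1.2 cells for binding affinity to C-C chemokine receptor type 8 (Homo sapiens); a higher number here means a weaker inhibitor, a lower number a stronger inhibitor. Compound 1 `Cc1ccccc1C(=O)Nc1ccc(S(=O)(=O)NC2CCN(C(=O)C3CCCC3)CC2)c2ccccc12` gives 9.1 nM. Compound 2 `Cc1ccccc1C(=O)Nc1ccc(S(=O)(=O)NC2CCN(C(=O)CCCN)CC2)c2ccccc12`, with 3-aminopropyl on the carbonyl carbon, gives 1.6 nM. Compound 3 `Cc1ccccc1C(=O)Nc1ccc(S(=O)(=O)NC2CCN(C(=O)CCCCN)CC2)c2ccccc12`, with 4-aminobutyl in the same place, gives 199 nM, the highest of the three numbers: the step of a 22-fold higher number from compound 1 to compound 3 (1.34 log units; beyond the scatter) is large, and the step of a 120-fold higher number from compound 2 to compound 3 (2.09 log units; beyond the scatter) is larger still, while the step of a 5.7-fold lower number from compound 1 to compound 2 (0.75 log units; beyond the scatter) runs the other way.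

Compound 4 `CCCNC(=O)N1CCC(NS(=O)(=O)c2ccc(NC(=O)c3ccccc3C)c3ccccc23)CC1` departs from compound 3 by one change: propylamino in place of 4-aminobutyl on a carbonyl carbon. The new group carries no amino on a chain carbon, so the measured steps that bear on it are those in which the aminoalkyl chain is replaced or absent. Among the compounds with values here, compound 1, the only measured compound without such a chain, stands far below compound 3 in this assay, and the step of a 22-fold higher number from compound 1 to compound 3 (1.34 log units; beyond the scatter) shows how much the 4-aminobutyl chain costs against a group with no amino. Within the data shown here, a downward step of roughly that size, back toward the value of compound 1, is therefore expected, with an allowance for the urea linkage that none of the measured compounds carries. Compound 4 is estimated at 15 nM, within 3 nM to 80 nM, which means an expected step of a 13-fold lower number from compound 3 to compound 4 (1.12 log units; beyond the scatter).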

Compound 4, inhibition constant: 77.4 nM
For compound 4 the middle estimate is 5.2-fold (0.71 log units) below the measured one, within the range that was stated.
By their numbers in this assay, from the lowest: compound 2; then compound 1; then compound 4; then compound 3.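

In this assay, propylamino on a carbonyl carbon whose other neighbour is an amide-type nitrogen in a ring recovers only part of what 4-aminobutyl loses, with a 2.6-fold lower number from compound 3 to compound 4 (0.41 log units; beyond the scatter) as a modest step. A chain without a terminal amino group therefore does not by itself bring the number back to that of the cyclopentyl group, as an 8.5-fold higher number from compound 1 to compound 4 (0.93 log units; beyond the scatter) shows, and it stands much further from the 3-aminopropyl group, with a 48-fold higher number from compound 2 to compound 4 (1.68 log units; beyond the scatter) as a large step. Of the three open chains now measured at this position, only 3-aminopropyl gives a number lower than that of cyclopentyl, while 4-aminobutyl and propylamino both go against any rule that an open chain favours binding here.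

On these data alone, a propylamino chain ending in an amine, or cyclopentylamino on the same carbonyl carbon, would separate the effect of the linking nitrogen from that of the rest of the group, and that question stays open. Nothing available here accounts for the differences among these four groups.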